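Thiophen-2-yl to thiophen-3-yl at the limit of the assay

The compounds below may be only part of what the source reports. "The series", "measured", "known", "first", "only" and "open" are said of these compounds alone.

In a functional assay on U-373MG ATCC cells for inhibition, with U373 MG (Homo sapiens) as the target, read by MTT assay, with a stated time of 7 days (a higher number here means a weaker inhibitor of growth, a lower number a stronger inhibitor of growth), compound 1 `NC(=O)c1nc[nH]c1N/N=N/Cc1ccoc1` gives > 50000 nM, which is a limit of the assay and not a number. Compound 2 `NC(=O)c1nc[nH]c1N/N=N/Cc1cccs1` gives > 50000 nM, which is also a limit and not a number. Within the data shown here, the standing of compound 2 is therefore known only as a limit, and the one other value available is a limit too: the limit of > 50000 nM in this assay, at which 2 of the 2 values shown sit. Among the measured compounds shown here, the only measured step, a step that the two limits leave unreadable from compound 1 to compound 2, offers no size to carry forward.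

Compound 3 `NC(=O)c1nc[nH]c1N/N=N/Cc1ccsc1` has thiophen-3-yl in place of thiophen-2-yl on a saturated chain carbon bound to a double-bonded nitrogen, and the count for the change reads (thiophen-3-yl in place of thiophen-2-yl on a saturated chain carbon bound to a double-bonded nitrogen). For the measured compounds named here, no measured step gives a size or direction for this change in this assay, so no change beyond the scatter is expected. Compound 3 is expected to behave like its neighbours because of the limit of > 50000 nM in this assay, at which 2 of the 2 values shown sit. The expected step is a number no higher from compound 2 to compound 3 (the limit leaves the size open). For compound 3 the estimated value is 50000 nM, with an expected range of 25000 nM to 100000 nM. A further report as a limit is the likeliest outcome.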

Compound 3, concentration for 50% growth inhibition: > 50000 nM
Compound 3: no number, only a limit; the forecaster's own chance of this, stated with the estimate: 80%; the middle value lies on the limit itself.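

Compound 3 adds no readable step: the steps among compound 1, compound 2 and compound 3 cannot be read, as all three values are limits and not numbers. The series stands at a single limit: the limit of > 50000 nM in this assay, at which 3 of the 3 values shown sit. The compounds shown leave open whether any change to the shared core gives a readable number in this assay.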